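A few compounds are considered here, and "the series" means these few. Any claim that something is new, unique, unknown or untested is made for them only; others in the source may bear on it.

Measured in an ADME assay on microsomes from liver (Mus musculus, strain CD-1) for metabolic stability, read by LC-MS, tested at 2 uM; a lower number here means that the compound disappears faster, a higher number that the compound lasts longer:
- Compound 1 `CN1CCC(CNS(=O)(=O)c2ccccc2Nc2cc(-c3ccc4ccn(C)c4c3)c3nccnc3c2)C1`: 0.633 h
- Compound 2 `CN1CCCC(NS(=O)(=O)c2ccccc2Nc2cc(-c3ccc4ccn(C)c4c3)c3nccnc3c2)C1`: 0.483 h
- Compound 3 `Cn1ccc2ccc(-c3cc(Nc4cnccc4C(=O)NCc4cncnc4)cc4nccnc34)cc21`: 0.4 h

These three half-lives lie so close together that repeat measurements could not separate them. Compound 3, at 0.4 h, therefore cannot be ranked against compound 1 or compound 2.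

The next compound to consider is compound 4 `Cn1ccc2ccc(-c3cc(Nc4cnccc4C(=O)NC4CCNC(=O)C4)cc4nccnc34)cc21`. It has 2-oxopiperidin-4-yl in place of (pyrimidin-5-yl)methyl on an amide-type nitrogen.

Within the data shown here, only one measured step offers any guidance: a 1.3-fold lower number from compound 1 to compound 2 (0.12 log units; within the scatter). It exchanged (1-methylpyrrolidin-3-yl)methyl for 1-methylpiperidin-3-yl, and the number stayed within the scatter. That exchange sits on a sulfonamide nitrogen, however, so it is only a loose guide. Among the measured compounds shown here, no measured step touches the amide-type nitrogen that changes here, and no measured pair shows what this particular swap does.

With so little evidence, no shift beyond the scatter is expected in this assay. The estimated change is a 1.3-fold higher number from compound 3 to compound 4 (0.10 log units; within the scatter), which is too small to assign a firm direction. For compound 4 the expected half-life is 0.5 h, with an estimated range from 0.25 h to 1 h.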

Compound 4, half-life: > 1 h
Compound 4 ended at the assay's limit (the forecaster's own chance of this, stated with the estimate: 3%); middle value at least 2.0-fold (0.30 log units) away from the limit.
By their numbers in this assay, from the lowest: compounds 3, 2 and 1 (each within the scatter of the next). At a limit, above all of these: compound 4.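

On the amide-type nitrogen, 2-oxopiperidin-4-yl in place of (pyrimidin-5-yl)methyl gives an at least 2.5-fold higher number from compound 3 to compound 4 (0.39 log units; beyond the scatter) in this assay, so a change at this position can shift the half-life by more than repeat measurements would scatter. Among these compounds, the only earlier step, made on a sulfonamide nitrogen and not at this position, gave a 1.3-fold lower number from compound 1 to compound 2 (0.12 log units; within the scatter), so it offered no such sign. Compound 4 stands at a limit of the assay, > 1 h, and the size of its step is therefore a lower bound: the limit of > 1 h in this assay, at which 1 of the 4 values shown sits.

The swap changes several things at once, replacing an aromatic ring with two hetero atoms by a non-aromatic ring that carries a carbonyl and an extra hydrogen-bond donor, and the compounds shown cannot say which of these features goes with the longer half-life. As far as these compounds go, a plain piperidin-4-yl without the ring carbonyl, or a cyclohexyl group, on the same amide-type nitrogen would help to separate these features, while how far compound 4 lies past the limit and whether the swap carries over to other compounds also remain open.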